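Working notes: adding ethoxy to compound 3

The compounds below may be only part of what the source reports. "The series", "measured", "known", "first", "only" and "open" are said of these compounds alone.

Values in a functional assay on CCRF-CEM cells (Homo sapiens) for antiproliferative activity, read by fluorescence and resazurin assay, with a stated time of 48 h; on this read-out lower numbers stand for stronger inhibition and higher numbers for weaker inhibition:
- compound 1 `CCOc1ccc2nc(Cl)c(/C=N/NC(=O)c3cc4cc([N+](=O)[O-])ccc4oc3=O)cc2c1`: 15700 nM
- compound 2 `CCOc1ccc2nc(Cl)c(/C=N/NC(=O)c3cc4ccccc4oc3=O)cc2c1`: 6320 nM
- compound 3 `O=C(N/N=C/c1cc2ccccc2nc1Cl)c1cc2cc(Br)ccc2oc1=O`: 7450 nM

Compound 3 at 7450 nM lies within the scatter of compound 2 at 6320 nM. Compound 1 at 15700 nM has a higher number than compound 3, beyond the scatter.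

The next compound is compound 4 `CCOc1ccc2nc(Cl)c(/C=N/NC(=O)c3cc4cc(Br)ccc4oc3=O)cc2c1`, related to compound 3 by ethoxy in place of hydrogen on an aromatic carbon. Among the measured compounds shown here, no measured step isolates this change. For the measured compounds named here, the only measured step, a 2.5-fold lower number from compound 1 to compound 2 (0.40 log units; beyond the scatter), replaces nitro with hydrogen, so it bears only indirectly and shows a modest move among compounds that carry ethoxy. Compound 2, which carries ethoxy, gives 6320 nM, but it differs from compound 3 in more than that group. In this assay, no step beyond the scatter is therefore expected. The expected change is a 1.0-fold higher number from compound 3 to compound 4 (0.00 log units; within the scatter). For compound 4 the estimated value is 7500 nM, with an expected range of 3500 nM to 16000 nM.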

Compound 4, half-maximal inhibitory concentration: 12900 nM
For compound 4 the middle estimate is 1.7-fold (0.24 log units) below the measured one; measured number inside the range.
By their numbers in this assay, from the lowest: compounds 2, 3, 4 and 1 (each within the scatter of the next, the first and the last beyond it).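

In this assay, among the compounds shown here, ethoxy in place of hydrogen on this aromatic carbon gives a 1.7-fold higher number from compound 3 to compound 4 (0.24 log units; within the scatter), so the one pair that isolates this change shows no step beyond the scatter, and that holds with bromo in the other place. With ethoxy present throughout, bromo in place of hydrogen gives a 2.0-fold higher number from compound 2 to compound 4 (0.31 log units; beyond the scatter), a modest step beyond the scatter, while bromo in place of nitro gives a 1.2-fold lower number from compound 1 to compound 4 (0.09 log units; within the scatter), which does not separate those two groups. Nothing available here accounts for these steps.

Going by these compounds, the ethoxy change rests on this single pair, so its size with hydrogen or nitro in the other place remains open. Also open, on these data alone, is how a longer chain, an amine or a carboxylic acid in place of ethoxy on this carbon would read.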